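The source may hold more compounds than are shown below. What is called first, only, known or untested is meant among the compounds shown, and "the series" means these compounds.

Three compounds share one core and were tested in a functional assay on NCI-H661 cells (Homo sapiens) for cytotoxicity, read by WST assay, with a stated time of 72 h; a higher number here means a weaker inhibitor, a lower number a stronger inhibitor. Compound 1 `COc1cc2c(Nc3nc4ccc(C(=O)Nc5c(C)cccc5Cl)cc4s3)ncnc2cc1OCCCN1CCCCC1C` gives 5300 nM in this assay. Compound 2 `COc1cc2c(Nc3nc4ccc(C(=O)Nc5c(C)cc(C)cc5C)cc4s3)ncnc2cc1OCCCN1CCCCC1C` gives 8800 nM in this assay. Compound 3 `COc1cc2c(Nc3nc4ccc(C(=O)Nc5c(C)cccc5Cl)cc4s3)ncnc2cc1OCCCN1CCCCC1` gives 13800 nM in this assay, the highest of the three numbers. The unmeasured compound 4 `COc1cc2c(Nc3nc4ccc(C(=O)Nc5c(C)cc(C)cc5C)cc4s3)ncnc2cc1OCCCN1CCCCC1` has not yet been tested in this assay.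

Compound 2 differs from compound 1 by 2,4,6-trimethylphenyl in place of 2-chloro-6-methylphenyl on an amide-type nitrogen. This change made a 1.7-fold higher number from compound 1 to compound 2 (0.22 log units; within the scatter). Compound 3 differs from compound 1 in the core by hydrogen in place of methyl on a saturated ring carbon, which made a 2.6-fold higher number from compound 1 to compound 3 (0.42 log units; beyond the scatter).

Compound 4 differs from compound 3 by 2,4,6-trimethylphenyl in place of 2-chloro-6-methylphenyl on an amide-type nitrogen. This is the same change as the one from compound 1 to compound 2, and it sits at the same place, on an amide-type nitrogen whose other neighbour is a carbonyl carbon; the only difference between the two pairs is the core, as described above. Because the earlier change gave a 1.7-fold higher number from compound 1 to compound 2 (0.22 log units; within the scatter), the step from compound 3 to compound 4 is expected to be similar, estimated as a 1.6-fold higher number from compound 3 to compound 4 (0.20 log units; within the scatter). Going by the values given here, only one prior example of this change exists, and it lies within the scatter, so the expectation is weakly founded. For compound 4 the value in this assay is estimated at 22000 nM, with a likely range from 10000 nM to 50000 nM.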

Compound 4, half-maximal inhibitory concentration: 10000 nM
Compound 4: middle estimate off by 2.2-fold (0.34 log units), on the high side; measured number inside the range.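

In this assay, putting 2,4,6-trimethylphenyl in place of 2-chloro-6-methylphenyl on the amide-type nitrogen gave a 1.4-fold lower number from compound 3 to compound 4 (0.14 log units; within the scatter), and this step cannot be told apart from its earlier counterpart on the other core: the same change on two cores in this assay, a 1.7-fold higher number (0.22 log units; within the scatter) from compound 1 to compound 2 and a 1.4-fold lower number (0.14 log units; within the scatter) from compound 3 to compound 4, 2.3-fold (0.36 log units) apart, within the scatter of two such steps. Putting hydrogen in place of methyl on the saturated ring carbon gave a 1.1-fold higher number from compound 2 to compound 4 (0.06 log units; within the scatter), and this step also cannot be told apart from its counterpart: the same change on two cores in this assay, a 2.6-fold higher number (0.42 log units; beyond the scatter) from compound 1 to compound 3 and a 1.1-fold higher number (0.06 log units; within the scatter) from compound 2 to compound 4, 2.3-fold (0.36 log units) apart, within the scatter of two such steps. Both changes are therefore consistent with carrying over from one core to the other, but this is not proof of transfer: each comparison rests on a single pair of steps, and a real dependence on the core smaller than the usual scatter would go unseen.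

The compounds shown leave open how other groups would behave in the same two places, such as a plain phenyl or a pyridyl group on the amide-type nitrogen, or an ethyl group in place of the methyl on the saturated ring carbon. They also leave open whether the same agreement between the two cores would appear on a third core or in a different cell line.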